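The source may hold more compounds than are shown below. What is called first, only, known or untested is meant among the compounds shown, and "the series" means these compounds.

Measured in a functional assay on A549 cells (Homo sapiens) for inhibition, read by MTT assay, with a stated time of 48 h; on this read-out lower numbers stand for stronger inhibition and higher numbers for weaker inhibition:
- Compound 1 `O=C(Nc1ccccn1)Nc1cc(-c2cncnc2)ccc1OC(F)(F)F`: 15200 nM
- Compound 2 `COc1ccc(-c2ccc(OC(F)(F)F)c(NC(=O)Nc3nccs3)c2)cn1`: 35000 nM

Compound 2 has the higher of the two numbers, which makes it the weaker inhibitor of the pair. Compound 3 `O=C(Nc1nccs1)Nc1cc(-c2cncnc2)ccc1OC(F)(F)F` differs from compound 2 in one place: pyrimidin-5-yl in place of 6-methoxypyridin-3-yl on an aromatic carbon. Going by the values given here, no measured pair shows this change alone. Compound 1 already carries pyrimidin-5-yl and gives 15200 nM, so a small downward move in this assay is expected, about the size of the usual scatter. The estimated change is a 1.8-fold lower number from compound 2 to compound 3 (0.27 log units; within the scatter). For compound 3 the expected value is 19000 nM, with an estimated range of 8000 nM to 45000 nM.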

Compound 3, half-maximal inhibitory concentration: 17600 nM
The estimate for compound 3 lay 1.1-fold (0.03 log units) above the measured number; the range from low to high includes it.
By their numbers in this assay, from the lowest: compounds 1, 3 and 2 (each within the scatter of the next, the first and the last beyond it).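

In this assay, pyrimidin-5-yl in place of 6-methoxypyridin-3-yl gives a 2.0-fold lower number from compound 2 to compound 3 (0.30 log units; within the scatter) and so lies within the scatter: on this aromatic carbon, para to the trifluoromethoxy group, the two rings cannot be told apart. With pyrimidin-5-yl held fixed, 1,3-thiazol-2-yl in place of pyridin-2-yl on the amide-type nitrogen gives a 1.2-fold higher number from compound 1 to compound 3 (0.06 log units; within the scatter) and is also within the scatter. No supporting data accompany these results. Going by these compounds, whether an amine or a carboxylic acid on this aromatic carbon would give a step beyond the scatter stays open.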